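This account rests on a few compounds, and the source may have more. Where it says the series, first, only, none or still open, it means among the compounds named here.

Of the compounds shown here, three sharing one core have been tested in a physicochemical assay for solubility, using the shake flask method, in simulated intestinal fluid, measured as kinetic solubility, with a stated time of 2 h, at 25 degrees C, at pH 6.5; a higher number here means a more soluble compound, a lower number a less soluble compound: compound 1 (`Cc1noc(-c2nc(C)c3c(c2N)C(=O)N(Cc2ccc(-c4ccncc4)cc2)C3=O)n1`), compound 2 (`COc1ccccc1CN1C(=O)c2c(C)nc(-c3nc(C)no3)c(N)c2C1=O`) and compound 3 (`Cc1noc(-c2nc(C)c3c(c2N)C(=O)N(Cc2ccc(C#N)cc2)C3=O)n1`). Compound 1 gives < 5000 nM as a limit of the assay, not a number. Compound 2 gives < 5000 nM as a limit too. Compound 3 gives < 5000 nM as a limit as well, and so it has no exact place on the scale. All the evidence so far rests on one point, the limit of < 5000 nM in this assay, at which 3 of the 3 values shown sit, and no exact reading.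

Compound 4 (`Cc1noc(-c2nc(C)c3c(c2N)C(=O)N(Cc2ccc(C(N)=O)cc2)C3=O)n1`) has carbamoyl in place of cyano on an aromatic carbon, and the counted change is carbamoyl in place of cyano on an aromatic carbon in full. Among the measured compounds shown here, two measured steps bear on this. The closer one is a step that the two limits leave unreadable from compound 1 to compound 3 with cyano in place of pyridin-4-yl on an aromatic carbon. The other is a step that the two limits leave unreadable from compound 2 to compound 3 with 4-cyanophenyl in place of 2-methoxyphenyl. Neither has a readable size, and no step beyond the usual scatter is expected in this assay in either direction. Another limit is the most likely report. The estimated change is a step that the limit leaves unreadable from compound 3 to compound 4 at most a modest one. For compound 4 the estimate is 3500 nM as the expected value, within an expected range from 1000 nM to 10000 nM in all.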

Compound 4, solubility: < 5000 nM
Compound 4: a limit, no number (the forecaster's own chance of this, stated with the estimate: 80%); the middle value lies beyond the limit too.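

Compound 4 gives a limit of the assay, not a number, and its steps from compound 1, compound 2 and compound 3 in this assay cannot be read. The whole series now rests on one point: the limit of < 5000 nM in this assay, at which 4 of the 4 values shown sit.

The compounds shown leave open where any of the four sits on the scale, and whether the groups that differ among them change the reading at all.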